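This account rests on a few compounds, and the source may have more. Where it says the series, first, only, none or still open, it means among the compounds named here.

Measured compounds:
compound 1 `COc1ccc(/C=C/C(=O)OC[C@H]2O[C@@H](O[C@@H]3OC=C[C@@]4(O)[C@H](O)C[C@](C)(O)[C@@H]34)[C@H](O)[C@@H](O)[C@@H]2O)cc1`: 60.3%
compound 2 `COc1ccc(/C=C\C(=O)O[C@@]2(C)C[C@@H](O)[C@]3(O)C=CO[C@@H](O[C@@H]4O[C@H](CO)[C@@H](O)[C@H](O)[C@H]4O)[C@@H]32)cc1`: 49.6%
compound 3 `N#Cc1cc2c(cc1[N+](=O)[O-])=NC(=O)C(=O)N=2`: 61.6%

All three were run in a functional assay (Cortical neurone cells, Rattus norvegicus, strain Sprague-Dawley), read by spectrophotometry and LDH release, with stated times of 1 h and 24 h, tested at 10 uM; on this read-out higher numbers stand for a stronger effect at the one concentration tested and lower numbers for a weaker effect. On these numbers compound 2 stands lowest of the three; compound 1 lies higher by a margin beyond the usual scatter, and compound 3 lies higher still, also beyond the scatter. Within the data shown here, no two of the measured compounds differ in a single place, so no structural step within the measured set can be read off.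

Compound 4 `COc1ccc(/C=C/C(=O)O[C@@]2(C)C[C@@H](O)[C@]3(O)C=CO[C@@H](O[C@@H]4O[C@H](CO)[C@@H](O)[C@H](O)[C@H]4O)[C@@H]32)cc1` has not yet been run. Relative to compound 2: the two compounds have the same atoms and bonds and differ only in configuration as drawn: 1 of 11 stereo elements differ; a double bond is drawn Z in compound 2 and E in compound 4. Among the measured compounds shown here, nothing among the measured compounds isolates the effect of redrawing one double bond from Z to E, so the expectation for this change rests on weak ground. Compound 1 also carries an E double bond and gave a higher number than compound 2, but it differs from compound 2 in more than that one place, so its value cannot be read as the step itself. The expected step is therefore small, a number 5.4 percentage points higher from compound 2 to compound 4 (within the scatter), leaning slightly upward but not clearly beyond the scatter. Compound 4 is expected to give about 55% in this assay, with a range from 42% to 68%.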

Compound 4, a percentage reported as activity, at one concentration (the size of the read-out at that concentration, not a potency): 58.9%
Compound 4: the middle estimate sits 3.9 percentage points below what was measured, within the range that was stated.
By their numbers in this assay, from the lowest: compounds 2, 4, 1 and 3 (each within the scatter of the next, the first and the last beyond it).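

Redrawing one double bond from Z to E gives the first single-place reading in this series: in this assay the step is a number 9.3 percentage points higher from compound 2 to compound 4 (within the scatter). Taken alone, this change of geometry is therefore not shown to alter the read-out beyond the usual variation, and as the figures come from one concentration, they say nothing about potency. The reading is a clean one, with no second structural change to separate from it: the fact that compounds 2 and 4 differ only in the configuration as drawn.

The other gaps among the compounds shown cannot be read as steps, as no other pair differs in a single place, so this double bond remains the only position with a singly read change. Still open, from the compounds shown here alone, is whether a carboxylic acid or an amine in place of the methoxy group, or an amide in place of the ester, would give a step beyond the scatter in this assay, and whether the double-bond pair would stay this close at other concentrations.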